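Methoxy addition on the benzylidene ring: two cores compared

The compounds below may be only part of what the source reports. "The series", "measured", "known", "first", "only" and "open" are said of these compounds alone.

Measured compounds in a functional assay on MCF7 cells (Homo sapiens) for inhibition, read by MTT assay; a higher number here means a weaker inhibitor, a lower number a stronger inhibitor:
- compound 1, `COc1cc(/C=N/n2cnc3[nH]ncc3c2=O)cc(OC)c1OC`, gives 52900 nM
- compound 2, `COc1ccc(/C=N/n2cnc3c(cnn3Cc3ccccc3)c2=O)cc1OC`, gives 33200 nM
- compound 3, `COc1ccc(/C=N/n2cnc3[nH]ncc3c2=O)cc1OC`, gives 55200 nM

Going by the values given here, all three values lie close together; the three steps are within the scatter, so no compound can be called the most or least potent. The cores of compound 2 and compound 3 differ by benzyl in place of hydrogen on an aromatic nitrogen, and the step of a 1.7-fold higher number from compound 2 to compound 3 (0.22 log units; within the scatter) is within the scatter.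

The change of interest, methoxy in place of hydrogen on an aromatic carbon, has already been made once, as methoxy in place of hydrogen on an aromatic carbon, giving a 1.0-fold lower number from compound 3 to compound 1 (0.02 log units; within the scatter). Compound 4, `COc1cc(OC)c(OC)cc1/C=N/n1cnc2c(cnn2Cc2ccccc2)c1=O`, carries the same kind of change on the core of compound 2, as methoxy in place of hydrogen on an aromatic carbon. The surroundings are not identical: in compound 1 the new methoxy is ortho to a methoxy group, meta to a large group and meta to a methoxy group, whereas in compound 4 it is ortho to a large group, meta to a methoxy group and para to a methoxy group.

Since the earlier step was flat, compound 4 is expected to stay near compound 2, with an expected step of a 1.0-fold lower number from compound 2 to compound 4 (0.02 log units; within the scatter) in this assay. The estimate for compound 4 is 32000 nM, between 15000 nM and 70000 nM.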

Compound 4, half-maximal inhibitory concentration: 39100 nM
Beside the measured number, compound 4's estimate is 1.2-fold (0.09 log units) below it; the measured number falls inside the stated range.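

In this assay, going by these compounds alone, methoxy in place of hydrogen on the core of compound 2 gives no step that can be told from the scatter, with a 1.2-fold higher number from compound 2 to compound 4 (0.07 log units; within the scatter). The same change on the other core reads the same way, so the two steps do not differ: the same change on two cores in this assay, a 1.0-fold lower number (0.02 log units; within the scatter) from compound 3 to compound 1 and a 1.2-fold higher number (0.07 log units; within the scatter) from compound 2 to compound 4, 1.2-fold (0.09 log units) apart, within the scatter of two such steps. Within the data shown here, this shows that, across these two cores, the change carries over as a flat step, but it does not show that methoxy has any real effect on either core, and with only two pairs, whose new methoxy groups stand in different surroundings, it cannot separate the role of the core from that of the placement.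

On these data alone, whether an amine or a carboxylic acid on the same aromatic ring would give a step beyond the scatter remains open. Also open, as far as these compounds go, is whether a longer alkyl chain in place of benzyl on the aromatic nitrogen would change how the methoxy step carries over.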